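A few compounds are considered here, and "the series" means these few. Any claim that something is new, unique, unknown or untested is made for them only; others in the source may bear on it.

Values in a functional assay; a higher number here means a weaker inhibitor, a lower number a stronger inhibitor:
- compound 1 `CC(C)=CCOc1ccc2c(c1)OC(c1ccc(C)cc1C)CC2=O`: 8260 nM
- compound 2 `CC(C)=CCOc1cc(O)c2c(c1)OC(c1cccc(Cl)c1)CC2=O`: 6060 nM
- compound 3 `CC(C)=CCOc1cc(O)c2c(c1)OC(c1cccc(Br)c1)CC2=O`: 4040 nM
- compound 4 `CC(C)=CCOc1cc(O)c2c(c1)OC(c1ccc(C)cc1C)CC2=O`: not yet measured

Compound 3 at 4040 nM lies within the scatter of compound 2, while compound 1 reads a higher number, beyond the scatter. The next change puts 2,4-dimethylphenyl in place of 3-bromophenyl on a saturated ring carbon.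

Going by the values given here, only one measured step touches this group: a 1.5-fold lower number from compound 2 to compound 3 (0.18 log units; within the scatter). It is bromo in place of chloro on an aromatic carbon, so it is a much smaller change and only a loose guide. Compound 1 carries the same 2,4-dimethylphenyl on a core that differs from that of compound 3, and compound 1 at 8260 nM suggests a drift towards a higher number in this assay, though probably none beyond the scatter. The expected step is a 1.4-fold higher number from compound 3 to compound 4 (0.13 log units; within the scatter). For compound 4 the estimated value is 5500 nM, with an expected range of 2200 nM to 13000 nM.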

Compound 4, half-maximal inhibitory concentration: 6380 nM
Estimate against measurement, compound 4: 1.2-fold (0.06 log units) below; the range from low to high includes it.
By their numbers in this assay, from the lowest: compounds 3, 2, 4 and 1 (each within the scatter of the next, the first and the last beyond it).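

In this assay, going by these compounds alone, the first exchange of the whole aromatic group on the saturated ring carbon gives a 1.6-fold higher number from compound 3 to compound 4 (0.20 log units; within the scatter), and the exchange for 3-chlorophenyl gives a 1.1-fold higher number from compound 2 to compound 4 (0.02 log units; within the scatter), so 2,4-dimethylphenyl reads alike with either halogenated phenyl at this position. The hydroxy group can now be read alone, and hydroxy in place of hydrogen on an aromatic carbon gives a 1.3-fold lower number from compound 1 to compound 4 (0.11 log units; within the scatter), also with no change beyond the scatter. No measurement is available that would account for these flat steps.

All three aromatic groups shown are phenyl rings carrying only halogen or methyl, so the effect of an amine or a carboxylic acid on that ring remains open. Also open, going by these compounds, is whether a longer chain on the ether oxygen of the shared core would shift the number in this assay.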